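Trifluoromethyl to methyl swap across two related cores

The compounds below may be only part of what the source reports. "The series", "measured", "known", "first", "only" and "open" are said of these compounds alone.

Measured so far in a functional assay on CNE-2 cells (Homo sapiens) for cytotoxicity, read by MTT assay, with a stated time of 72 h; on this read-out lower numbers stand for stronger inhibition and higher numbers for weaker inhibition:
compound 1 `COc1cc2ncnc(NNC(=S)NC(=O)c3ccc(C)cc3)c2cc1OC` gives 33300 nM
compound 2 `COc1cc2ncnc(NNC(=S)NC(=O)c3ccc(C(F)(F)F)cc3)c2cc1OC` gives 16500 nM
compound 3 `O=C(NC(=S)NNc1ncnc2ccccc12)c1ccc(C(F)(F)F)cc1` gives 22500 nM

Compound 4 `Cc1ccc(C(=O)NC(=S)NNc2ncnc3ccccc23)cc1` has not yet been measured in this assay.

Compound 1 and compound 2 share one core; compound 3 and compound 4 share another. The difference between the two cores is not broken down here. In this assay the values of compound 2 and compound 3 lie close to one another, and all three measured numbers sit within the usual scatter of each other, so no order among them is claimed.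

One structural change appears in two pairs. In the first pair it is methyl in place of trifluoromethyl on an aromatic carbon, and it gave a 2.0-fold higher number from compound 2 to compound 1 (0.30 log units; within the scatter). In the second pair it is methyl in place of trifluoromethyl on an aromatic carbon, the same change at a place described in the same words, so it is taken as the same change made on a different core.

Within the data shown here, the step from compound 3 to compound 4 is expected to be a 2.0-fold higher number from compound 3 to compound 4 (0.30 log units; within the scatter), because a 2.0-fold higher number from compound 2 to compound 1 (0.30 log units; within the scatter) is the only precedent for this change and it was small. Compound 4 is therefore expected to give about 45000 nM in this assay, with a plausible range from 20000 nM to 100000 nM. This rests on a single pair; any larger move in either direction would not be surprising given how close all three measured values already are.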

Compound 4, half-maximal inhibitory concentration: 17200 nM
For compound 4 the middle estimate is 2.6-fold (0.42 log units) above the measured one; measured number outside the range, below it.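

In this assay, methyl in place of trifluoromethyl gives a 1.3-fold lower number from compound 3 to compound 4 (0.12 log units; within the scatter), so on this core the change leaves the number within the scatter. Set beside the earlier step, the two cores do not separate on this change: the same change on two cores in this assay, a 2.0-fold higher number (0.30 log units; within the scatter) from compound 2 to compound 1 and a 1.3-fold lower number (0.12 log units; within the scatter) from compound 3 to compound 4, 2.6-fold (0.42 log units) apart, within the scatter of two such steps. Among these compounds, the two pairs therefore give no sign that the outcome of this change depends on the core, and on both cores it stays small; they do not show that the change behaves identically on the two cores or that it would stay small on any other core, and with only two pairs, both within the scatter, a modest core dependence could go unseen.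

The compounds shown leave open whether a different group on the aromatic carbon para to a large group, such as an amine, a carboxylic acid or a longer chain, would move the number beyond the scatter in this assay. They also leave open whether the flat picture for methyl and trifluoromethyl holds in cell lines other than the one tested here.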